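The source may report more compounds than this note shows. Statements on the series, on what has been measured and on what is new or still open speak of the compounds shown alone.

In a functional assay on HCT-116 cells (Homo sapiens) for antiproliferative activity (a lower number here means a stronger inhibitor, a higher number a weaker inhibitor), compound 1 `Cc1c2c(n3c1CCNC[C@@H](C)[C@H](C)Nc1cc-3ccc1C(N)=O)CC(C)(C)CC2=O` gives 24 nM as the lowest of the three numbers measured. Compound 2 `Cc1c2c(n3c1CCCN(C)[C@@H](C)[C@H](C)Nc1cc-3ccc1C(N)=O)CC(C)(C)CC2=O` gives 51 nM and compound 3 `Cc1c2c(n3c1CCCN(C(=O)CO)[C@@H](C)[C@H](C)Nc1cc-3ccc1C(N)=O)CC(C)(C)CC2=O` gives 51 nM here, both beyond the scatter from compound 1. The change (2-methoxyethyl)carbonyl in place of hydrogen on an amine nitrogen in a ring puts (2-methoxyethyl)carbonyl in place of hydrogen on an amine nitrogen in a ring, which leads from compound 1 to compound 4 `COCCC(=O)N1CCc2c(C)c3c(n2-c2ccc(C(N)=O)c(c2)N[C@@H](C)[C@H](C)C1)CC(C)(C)CC3=O` as the next case. The closest measured step is no change at the digits printed from compound 2 to compound 3 (within the scatter) with (hydroxymethyl)carbonyl in place of methyl on an amine nitrogen in a ring. Among the compounds with values here, no measured step starts from the hydrogen of compound 1, so this guide is loose. A rise towards compound 3 at 51 nM is expected rather than a fall. The expected move is a 2.1-fold higher number from compound 1 to compound 4 (0.32 log units; beyond the scatter) towards a weaker inhibitor. For compound 4 the estimated value is 50 nM with an expected range from 20 nM to 120 nM as the upper end.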

Compound 4, half-maximal inhibitory concentration: 38 nM
For compound 4 the middle estimate is 1.3-fold (0.12 log units) above the measured one; the range from low to high includes it.
By their numbers in this assay, from the lowest: compounds 1, 4, 2 and 3 (each within the scatter of the next, the first and the last beyond it).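

Within this assay the swap of hydrogen for (2-methoxyethyl)carbonyl on the amine nitrogen in a ring gives a 1.6-fold higher number from compound 1 to compound 4 (0.20 log units; within the scatter) and so shows that this nitrogen can carry this six-heavy-atom chain with no change beyond the scatter. The earlier compounds shown here held no step that started from this hydrogen. No measured evidence here explains this result. Still open, going by these compounds, is how this nitrogen would respond to an acetyl group, a longer chain, or a chain ending in an amine or a carboxylic acid.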